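The source may report more compounds than this note shows. Statements on the series, on what has been measured and on what is new or still open speak of the compounds shown alone.

Compound 1 `CN(C)c1ccc(/C=N/c2nc(NC3CC3)c3ncn(C4C=CC(CO)C4)c3n2)cc1`: > 100000 nM
Compound 2 `O=[N+]([O-])c1ccc(/C=N/c2nc(NC3CC3)c3ncn(C4C=CC(CO)C4)c3n2)cc1`: 12000 nM

In a functional assay on CCRF-CEM cells (Homo sapiens) for cytotoxicity (a lower number here means that less compound is tolerated, a higher number that more compound is tolerated), compound 1 gives > 100000 nM, which is a limit of the assay. For the measured compounds named here, compound 2, at 12000 nM, holds the only actual number so far. Compound 3 `COc1ccc(/C=N/c2nc(NC3CC3)c3ncn(C4C=CC(CO)C4)c3n2)c(O)c1` differs from it as follows: 2-hydroxy-4-methoxyphenyl in place of 4-nitrophenyl on a carbon with a double bond to nitrogen. Going by the values given here, one measured step bears on this change, an at least 8.3-fold lower number from compound 1 to compound 2 (0.92 log units; beyond the scatter). Compound 3 has no nitro, as compound 1 has none, so a moderate move towards a higher number is expected. The expected change is a 2.9-fold higher number from compound 2 to compound 3 (0.46 log units; beyond the scatter). For compound 3 the estimated value is 35000 nM, within an expected range of 10000 nM to 100000 nM.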

Compound 3, half-maximal cytotoxic concentration: 100000 nM
Compound 3: the middle estimate sits 2.9-fold (0.46 log units) below what was measured; the measured number falls inside the stated range.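

Read in this assay, the change on the carbon with a double bond to nitrogen now has a measured number at both ends: an 8.3-fold higher number from compound 2 to compound 3 (0.92 log units; beyond the scatter). Of the three compounds, only compound 2, with its 4-nitrophenyl, sits at the lower number, so the drop seen earlier does not carry over to 2-hydroxy-4-methoxyphenyl. With 2-hydroxy-4-methoxyphenyl in place of 4-(dimethylamino)phenyl, the data give a number no higher from compound 1 to compound 3 (the limit leaves the size open). The size of this step cannot be read, since the value of compound 1 is a limit: the limit of > 100000 nM in this assay, at which 1 of the 3 values shown sits.

From the compounds shown here alone, whether a plain phenyl or a 4-cyanophenyl here would give a number as low as that of compound 2, at 12000 nM, stays open. So does whether the hydroxy or the methoxy alone accounts for the step.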